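Acetyl for Methoxymethyl on the Aryl Nitrogen of a Pyrimidine Series

The source may report more compounds than this note shows. Statements on the series, on what has been measured and on what is new or still open speak of the compounds shown alone.

Measured compounds and their values:
compound 1, `CCCCN(c1ccnc(Nc2ccc(C#N)cc2)n1)c1c(F)cc(-c2ccc(C#N)cc2)cc1F`: 211000 nM
compound 2, `CC(O)CN(c1ccnc(Nc2ccc(C#N)cc2)n1)c1c(F)cc(-c2ccc(C#N)cc2)cc1F`: 9800 nM
compound 3, `COCN(c1ccnc(Nc2ccc(C#N)cc2)n1)c1c(F)cc(-c2ccc(C#N)cc2)cc1F`: 238000 nM

These three share one core and differ only in the group carried on the nitrogen joining the two aromatic parts. In an ADME assay on MT4 cells (Homo sapiens) for cytotoxicity, read by MTT assay, with a stated time of 5 days (on this read-out lower numbers stand for higher toxicity in this test and higher numbers for lower toxicity in this test), compound 3 gives the highest number of the three; its nearest neighbour is compound 1, and that gap is within the scatter, so the two cannot be ranked. The one large effect seen is a 22-fold lower number from compound 1 to compound 2 (1.33 log units; beyond the scatter) and, seen from the other side, a 24-fold higher number from compound 2 to compound 3 (1.39 log units; beyond the scatter).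

Compound 4, `CC(=O)N(c1ccnc(Nc2ccc(C#N)cc2)n1)c1c(F)cc(-c2ccc(C#N)cc2)cc1F`, carries acetyl in place of methoxymethyl on a nitrogen on an aromatic ring. For the measured compounds named here, no measured step puts an acetyl at this place, so the measured steps bear on it only indirectly: the large changes accompanied the group bearing a hydroxyl, while the exchange of one chain without a hydroxyl for another, a 1.1-fold higher number from compound 1 to compound 3 (0.05 log units; within the scatter), was within the scatter. Compound 4 is therefore expected to stay close to compound 3, with at most a modest drop, a 1.8-fold lower number from compound 3 to compound 4 (0.26 log units; within the scatter). The estimate for compound 4 in this assay is 130000 nM, with a range from 25000 nM to 320000 nM.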

Compound 4, half-maximal cytotoxic concentration: > 268000 nM
Compound 4: only a limit was reported; the forecaster's own chance of this, stated with the estimate: 25%; middle value at least 2.0-fold (0.31 log units) from the limit.
By their numbers in this assay, from the lowest: compound 2; then compounds 1 and 3 (each within the scatter of the next). At a limit, above all of these: compound 4.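

In this assay, compound 4 is reported only as a limit, not as a number: the limit of > 268000 nM in this assay, at which 1 of the 4 values shown sits. Set against the two chains without a hydroxyl, this gives only an at least 1.1-fold higher number from compound 3 to compound 4 (0.05 log units; that floor lies within the scatter) and an at least 1.2-fold higher number from compound 1 to compound 4 (0.10 log units; that floor lies within the scatter), so acetyl cannot be ranked against methoxymethyl or butyl on this nitrogen. The gap to the hydroxyl-bearing chain is firm, with an at least 27-fold higher number from compound 2 to compound 4 (1.43 log units; beyond the scatter), so acetyl on this nitrogen shows none of the drop seen with 2-hydroxypropyl, and among the four compounds only compound 2 stands apart.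

As far as these compounds go, how far the true value of compound 4 lies past its limit stays unknown. From the compounds shown here alone, it is also open whether the low number of compound 2 follows the hydroxyl itself or the chain carrying it, and a shorter hydroxyethyl chain or an amine on this nitrogen would bear on that.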